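From Hydroxy to Fluoro in Compound 4

The compounds below may be only part of what the source reports. "The series", "measured", "known", "first", "only" and "open" are said of these compounds alone.

In a functional assay on MCF7 cells (Homo sapiens) for antiproliferative activity, read by MTT assay, with a stated time of 72 h (on this read-out lower numbers stand for stronger inhibition and higher numbers for weaker inhibition), compound 3 `COc1cc(-n2cnc3ccc(-c4ccc(O)cc4)cc32)cc(OC)c1OC` gives 4160 nM, within the scatter of compound 2 `COc1cc(-n2cnc3ccc(-c4ccc(Cl)cc4Cl)cc32)cc(OC)c1OC` at 5420 nM. Compound 1 `COc1cc(-n2cnc3ccc(-c4ccc(C(F)(F)F)cc4)cc32)cc(OC)c1OC` gives 760 nM. Compound 4 `COc1cc(-n2cnc3ccc(-c4ccc(F)cc4)cc32)cc(OC)c1OC` has fluoro in place of hydroxy on an aromatic carbon, para to a large group: fluoro in place of hydroxy on an aromatic carbon. The closest measured change is a 5.5-fold higher number from compound 1 to compound 3 (0.74 log units; beyond the scatter), where hydroxy took the place of trifluoromethyl. Read in reverse, that step suggests that removing hydroxy may bring a lower number. Compound 2 goes against this: it has no hydroxy, and the data show a 7.1-fold higher number from compound 1 to compound 2 (0.85 log units; beyond the scatter). A modest change is therefore expected, namely a 2.1-fold lower number from compound 3 to compound 4 (0.32 log units; beyond the scatter). For compound 4 the estimated value is 2000 nM, with an expected range from 700 nM to 5500 nM.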

Compound 4, half-maximal inhibitory concentration: 1770 nM
Estimate against measurement, compound 4: 1.1-fold (0.05 log units) above, and the stated range covers the measured number.
By their numbers in this assay, from the lowest: compound 1; then compound 4; then compounds 3 and 2 (each within the scatter of the next).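

In this assay, fluoro at this position, para to a large group, gives a clearly lower number than hydroxy (a 2.4-fold lower number from compound 3 to compound 4 (0.37 log units; beyond the scatter)). The 4-fluorophenyl group also does better than 2,4-dichlorophenyl (a 3.1-fold lower number from compound 2 to compound 4 (0.49 log units; beyond the scatter)), so a small single atom here can outperform two chlorines. Trifluoromethyl still stays ahead of fluoro (a 2.3-fold higher number from compound 1 to compound 4 (0.37 log units; beyond the scatter)), which puts compound 4 between compound 1 and the other two. Nothing available explains these differences. From the compounds shown here alone, whether an amine, a nitrile or a carboxylic acid at this position would fall nearer compound 1 or compound 3 remains open.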